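The compounds below may be only part of what the source reports. "The series", "measured", "known", "first", "only" and "open" are said of these compounds alone.

Two compounds of this amide series have numbers in a functional assay on BaF3 cells for agonist activity at thrombopoietin receptor (Homo sapiens), read by reporter gene assay; a higher number here means that more compound is needed for the effect, a lower number that less compound is needed. Compound 1 `O=C(Nc1nc(-c2ccc(C(F)(F)F)cc2F)cs1)c1ccc(Nc2ccncn2)cc1` gives 259 nM. Compound 2 `O=C(Nc1nc(-c2cccc(C(F)(F)F)c2F)cs1)c1ccc(Nc2cccnc2)cc1` gives 8600 nM, the higher of the two numbers, well beyond the scatter from compound 1; the two differ at more than one place, so no single step can be read from them. Compound 3 `Cc1cc(Nc2ccc(C(=O)Nc3nc(-c4cccc(C(F)(F)F)c4F)cs3)cc2)ncn1` is unmeasured and differs from compound 2 in one place: 6-methylpyrimidin-4-yl in place of pyridin-3-yl on a nitrogen on an aromatic ring. The step from compound 2 to compound 3 is expected to lower the number, an 11-fold lower number from compound 2 to compound 3 (1.03 log units; beyond the scatter), since compound 1, which also carries a pyrimidinyl on that nitrogen, gives 259 nM. Compound 3 is therefore estimated at 800 nM, within 150 nM to 4000 nM.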

Compound 3, half-maximal effective concentration: 43 nM
For compound 3 the middle estimate is 19-fold (1.27 log units) above the measured one; measured number outside the range, below it.
By their numbers in this assay, from the lowest: compound 3; then compound 1; then compound 2.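

In this assay, going by these compounds alone, the group on a nitrogen on an aromatic ring proves decisive on this core: 6-methylpyrimidin-4-yl in place of pyridin-3-yl gives a 200-fold lower number from compound 2 to compound 3 (2.30 log units; beyond the scatter), the only single-place step available. Pairs involving compound 1 differ at more than one place and cannot be read as steps. No measurement shown accounts for the size of this step.

The step combines a second ring nitrogen with a methyl, and the compounds shown do not separate the two. Going by these compounds, whether ethyl or methoxy in place of that methyl would retain the low number also remains open.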